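Replacing benzyl(methyl)amino with piperidin-1-yl in compound 2

The source may report more compounds than this note shows. Statements on the series, on what has been measured and on what is new or still open speak of the compounds shown alone.

Measured in a functional assay on FM3A cells (Mus musculus) for antiproliferative activity, read by cell counting, with a stated time of 2 days; on this read-out lower numbers stand for stronger inhibition and higher numbers for weaker inhibition:
- compound 1 `CCCCN(C)c1nc(N)c(C(=O)c2cc(OC)c(OC)c(OC)c2)s1`: 47000 nM
- compound 2 `COc1cc(C(=O)c2sc(N(C)Cc3ccccc3)nc2N)cc(OC)c1OC`: > 200000 nM, a limit of the assay

Compound 2 stands only at the limit of > 200000 nM in this assay, at which 1 of the 2 values shown sits. As far as these compounds go, this is a limit and not a number, so its true position in this assay is unknown.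

The next compound to be measured is compound 3 `COc1cc(C(=O)c2sc(N3CCCCC3)nc2N)cc(OC)c1OC`. It carries piperidin-1-yl in place of benzyl(methyl)amino on an aromatic carbon of the shared core: piperidin-1-yl in place of benzyl(methyl)amino on an aromatic carbon.

For the measured compounds named here, only one measured step bears on this change: an at least 4.2-fold higher number from compound 1 to compound 2 (0.62 log units; beyond the scatter). There, phenyl takes the place of propyl on a saturated chain carbon bound to a nitrogen on an aromatic ring, and the size of the step is known only as a lower bound. Compound 3 also gives up that six-membered aromatic ring, so its number is expected to fall back into the range of compound 1 at 47000 nM, though the ring of piperidin-1-yl has not been tested.

An estimated at least 3.3-fold lower number from compound 2 to compound 3 (0.52 log units; beyond the scatter) is therefore expected, toward a lower number. For compound 3 the expected value is 60000 nM, with an estimated range of 15000 nM to 200000 nM.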

Compound 3, half-maximal inhibitory concentration: 39000 nM
Beside the measured number, compound 3's estimate is 1.5-fold (0.19 log units) above it, within the range that was stated.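

In this assay, the move to piperidin-1-yl gives an at least 5.1-fold lower number from compound 2 to compound 3 (0.70 log units; beyond the scatter), which shows that this aromatic carbon, next to the ring nitrogen and next to the ring sulfur, can carry a non-aromatic ring without the loss seen with benzyl(methyl)amino, although the size of the step is known only as a lower bound: the limit of > 200000 nM in this assay, at which 1 of the 3 values shown sits.

Tying the substituent on the nitrogen back into a ring is a kind of change the earlier pair did not cover, and it gives a 1.2-fold lower number from compound 1 to compound 3 (0.08 log units; within the scatter), so the ring of piperidin-1-yl and the open butyl(methyl)amino cannot be told apart in this assay. Among these three compounds, only compound 2, the one that carries a six-membered aromatic ring of carbon in this group, stands apart from the others.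

The compounds shown leave open how a ring with a second hetero atom, such as morpholin-4-yl or piperazin-1-yl, or a smaller group such as dimethylamino, would behave at this position. They also leave open where compound 2 truly lies, and so how large the gap to the other two compounds is.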